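Swapping a fluoro for a pentyl chain on an acylguanidine

The source may report more compounds than this note shows. Statements on the series, on what has been measured and on what is new or still open speak of the compounds shown alone.

Measured compounds:
- compound 1 `Cc1cc(F)c(S(C)(=O)=O)cc1C(=O)N=C(N)N`: 44 nM
- compound 2 `Cc1c(C(=O)N=C(N)N)ccc(Cl)c1S(C)(=O)=O`: 1300 nM
- compound 3 `CCN(CC)Cc1cc(Br)c(S(C)(=O)=O)cc1C(=O)N=C(N)N`: 9500 nM

Of the compounds shown here, three have been tested in a functional assay for inhibition of sodium/hydrogen exchanger (Oryctolagus cuniculus); on this read-out higher numbers stand for weaker inhibition and lower numbers for stronger inhibition. Compound 1 gives 44 nM, the lowest of the three numbers and so the strongest inhibition seen. Compound 2 gives 1300 nM, a much higher number that lies beyond the scatter, and compound 3 gives 9500 nM, higher still. Among the measured compounds shown here, no pair of these differs in only one place, so none of them shows what a single change does.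

The next compound, compound 4 `CCCCCc1cc(C)c(C(=O)N=C(N)N)cc1S(C)(=O)=O`, differs from compound 1 in one place: pentyl in place of fluoro on an aromatic carbon. For the measured compounds named here, there is no measured step of this kind to lean on, so the size of the change is uncertain. Because compound 1 already stands at 44 nM and the entering group is far larger than the leaving fluoro, the expectation is a step toward weaker inhibition, a 6.8-fold higher number from compound 1 to compound 4 (0.83 log units; beyond the scatter), beyond the scatter. Compound 4 is therefore estimated at 300 nM in this assay, within a range from 60 nM to 2000 nM.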

Compound 4, half-maximal inhibitory concentration: 27 nM
Compound 4: the middle estimate sits 11-fold (1.05 log units) above what was measured; measured number below the stated range.
By their numbers in this assay, from the lowest: compounds 4 and 1 (each within the scatter of the next); then compound 2; then compound 3.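

In this assay, pentyl in place of fluoro on this aromatic carbon gives a 1.6-fold lower number from compound 1 to compound 4 (0.21 log units; within the scatter) and so leaves the two compounds indistinguishable. Among the compounds shown here, this is the first step in the set that changes a single place, and it shows that on this carbon, ortho to a methylsulfonyl group, a group of 5 heavy atoms and a group of 1 heavy atom give numbers within the scatter of each other. Nothing available explains why the two groups read alike.

From the compounds shown here alone, whether a longer chain, a phenyl ring or an amine on the same carbon would also stay within the scatter of compound 1 remains open. With only this one step at the position, no trend with chain length can be read from the compounds shown.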